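A Small Acetamide Variant in the Toxicity Test

The compounds below may be only part of what the source reports. "The series", "measured", "known", "first", "only" and "open" are said of these compounds alone.

The three measured compounds share one core and were all examined in a toxicity assay on THP-1 cells (Homo sapiens) for inhibition; on this read-out higher numbers stand for lower toxicity in this test and lower numbers for higher toxicity in this test. Compound 1 `COc1ccc(-c2cnc(NC(=O)c3cnc[nH]3)n2C)cc1` gives only a limit of the assay there, > 100000 nM. Compound 2 `COc1ccc(-c2cnc(NC(=O)CCc3ccccc3)n2C)cc1` likewise gives a limit, > 100000 nM. Compound 3 `COc1ccc(-c2cnc(NC(=O)c3cccc(O)c3)n2C)cc1` also returns a limit, > 100000 nM, so compound 3 stands at the same point as the other two and cannot be ranked against them. The steps a step that the two limits leave unreadable from compound 1 to compound 2, a step that the two limits leave unreadable from compound 1 to compound 3 and a step that the two limits leave unreadable from compound 2 to compound 3 are therefore all without a readable size, because the limit of > 100000 nM in this assay, at which 3 of the 3 values shown sit, gathers every value shown.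

Compound 4 `COc1ccc(-c2cnc(NC(C)=O)n2C)cc1` differs from compound 3 by methyl in place of 3-hydroxyphenyl on a carbonyl carbon. All three measured steps bear on this change only in that none of them yields a number, so no size or direction can be taken from them. The step of a number no higher from compound 3 to compound 4 (the limit leaves the size open) is thus expected to stay within the scatter, with compound 4 most likely again reported only as a limit. Compound 4 is estimated at 100000 nM, within 30000 nM to 300000 nM.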

Compound 4, half-maximal cytotoxic concentration: > 100000 nM
Compound 4 gave a limit, no number; the forecaster's own chance of this, stated with the estimate: 85%; the middle value lies on the limit itself.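

The steps linking compound 4 with compound 1, compound 2 and compound 3 cannot be read, because each result is only a limit: the limit of > 100000 nM in this assay, at which 4 of the 4 values shown sit. The compounds shown leave open how far apart they truly lie in this assay, and whether any of these changes on the carbonyl carbon alters the result at all.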